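Benzyloxy to Ethoxy: An Expected Loss of Inhibition

The compounds below may be only part of what the source reports. "The series", "measured", "known", "first", "only" and "open" are said of these compounds alone.

In a functional assay on RAW264.7 cells (Mus musculus) for inhibition, read by immunoassay, with a stated time of 12 h, tested at 30 uM (on this read-out lower numbers stand for less inhibition and higher numbers for more inhibition at the one concentration tested (going by the name of the read-out)), the three measured compounds give:
compound 1, `C=CCOc1ccccc1C1CC(=O)c2ccccc2O1`: 49.3%
compound 2, `CCCCCOc1ccccc1C1CC(=O)c2ccccc2O1`: 41.3%
compound 3, `O=C1CC(c2ccccc2OCc2ccccc2)Oc2ccccc21`: 93.2%

Compound 3 stands highest of these three numbers; its nearest neighbour is compound 1 and its furthest is compound 2, and both gaps lie beyond the scatter. Among the compounds with values here, compound 1 and compound 2 sit close together, as a number 8 percentage points lower from compound 1 to compound 2 (within the scatter) shows, so only the steps that reach compound 3 carry weight here: a number 43.9 percentage points higher from compound 1 to compound 3 (beyond the scatter) and a number 51.9 percentage points higher from compound 2 to compound 3 (beyond the scatter).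

Compound 4, `CCOc1ccccc1C1CC(=O)c2ccccc2O1`, differs from compound 3 in one place: methyl in place of phenyl on a saturated chain carbon bound to an oxygen on an aromatic ring

This is the reverse of the two large steps above: the phenyl that lifted compound 1 and compound 2 is taken away again. Because a number 43.9 percentage points higher from compound 1 to compound 3 (beyond the scatter) and a number 51.9 percentage points higher from compound 2 to compound 3 (beyond the scatter) were both large, a large fall in this assay is expected, bringing compound 4 back near where compound 1 and compound 2 stand.

Compound 4 is therefore estimated at 45%, with a likely range from 30% to 62%. That estimate means an expected step of a number 48.2 percentage points lower from compound 3 to compound 4 (beyond the scatter).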

Compound 4, a percentage reported as inhibition, at one concentration (the size of the read-out at that concentration, not a potency): 29.6%
The estimate for compound 4 lay 15.4 percentage points above the measured number, and the stated range ends above it.
By their numbers in this assay, from the lowest: compound 4; then compounds 2 and 1 (each within the scatter of the next); then compound 3.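

Taking the phenyl off this saturated chain carbon costs a great deal in this assay, seen as a number 63.6 percentage points lower from compound 3 to compound 4 (beyond the scatter). The ethoxy group also falls short of the two other non-aromatic groups at this place, with a number 11.7 percentage points lower from compound 2 to compound 4 (beyond the scatter) and a number 19.7 percentage points lower from compound 1 to compound 4 (beyond the scatter), so these groups are not interchangeable, although both steps are modest beside the loss of the phenyl. Nothing available here explains why these groups differ.

From the compounds shown here alone, whether the ring must be aromatic remains open, and a cyclohexyl in place of the phenyl would help to separate the presence of a ring from its aromatic character. Also open, going by these compounds, is how a phenyl carrying a fluorine, a methoxy or an amine would behave at this place.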